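From diethylamino to pyrrolidin-1-yl on a shared core

The compounds below may be only part of what the source reports. "The series", "measured", "known", "first", "only" and "open" are said of these compounds alone.

- compound 1 `CCNc1cc2nc(-c3ccccc3)nn(-c3ccccc3)c-2cc1=O` gives 240 nM
- compound 2 `CCN(CC)c1cc2nc(-c3ccccc3)nn(-c3ccccc3)c-2cc1=O` gives 2730 nM

In an ADME assay on GM00637 cells (Homo sapiens) for cytotoxicity, read by MTT assay, with a stated time of 72 h (a higher number here means a weaker inhibitor, a lower number a stronger inhibitor), compound 2 has the higher of the two numbers, 2730 nM against compound 1 at 240 nM (a gap beyond the scatter). Compound 3 `O=c1cc2n(-c3ccccc3)nc(-c3ccccc3)nc-2cc1N1CCCC1` has pyrrolidin-1-yl in place of diethylamino on an aromatic carbon and is still unmeasured. Going by the values given here, the one measured step that bears on this, an 11-fold higher number from compound 1 to compound 2 (1.06 log units; beyond the scatter) for ethyl in place of hydrogen on a nitrogen, is large, yet compound 3, like compound 2, has no such hydrogen, so no step of that size is expected. A change within the scatter, leaning towards a lower number, is expected, with a 1.5-fold lower number from compound 2 to compound 3 (0.18 log units; within the scatter) as the estimated step. For compound 3 the estimated value is 1800 nM with an expected range from 500 nM to 5000 nM in this assay.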

Compound 3, half-maximal inhibitory concentration: 1790 nM
The estimate for compound 3 lay 1.0-fold (0.00 log units) above the measured number, and the stated range covers the measured number.
By their numbers in this assay, from the lowest: compound 1; then compounds 3 and 2 (each within the scatter of the next).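

In this assay, closing the two ethyl arms of diethylamino into the pyrrolidin-1-yl ring on this aromatic carbon gives a 1.5-fold lower number from compound 2 to compound 3 (0.18 log units; within the scatter), so the ring itself changes little here. With the ring in place the gap to ethylamino remains, as a 7.5-fold higher number from compound 1 to compound 3 (0.87 log units; beyond the scatter), and of these three compounds only compound 1, which keeps a hydrogen on that nitrogen, gives the low number. No measurement shown offers a reason for this. As far as these compounds go, whether piperidin-1-yl, morpholin-4-yl or a primary amine on the same carbon would sit nearer compound 1 or compound 3 remains open.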